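Swapping a benzyl ether for a methoxyethyl ether

The compounds below may be only part of what the source reports. "The series", "measured", "known", "first", "only" and "open" are said of these compounds alone.

Going by the values given here, compound 2 `CC(C)(C)c1ccc(C/N=C(\S)NCc2ccc(NS(C)(=O)=O)cc2)c(OCc2ccccc2)c1` has the highest number of the two measured so far: in a functional assay for inhibition of Vanilloid receptor (Rattus norvegicus) (a higher number here means a weaker inhibitor, a lower number a stronger inhibitor), compound 2 gives 770 nM, whereas compound 1 `CCCOc1cc(C(C)(C)C)ccc1C/N=C(\S)NCc1ccc(NS(C)(=O)=O)cc1` gives 250 nM. Compound 3 `COCCOc1cc(C(C)(C)C)ccc1C/N=C(\S)NCc1ccc(NS(C)(=O)=O)cc1` differs from compound 2 by methoxymethyl in place of phenyl on a saturated chain carbon bound to an oxygen on an aromatic ring. Among the compounds with values here, only one measured step touches this place, and it was modest: a 3.1-fold higher number from compound 1 to compound 2 (0.49 log units; beyond the scatter), the larger group going with the higher number. A move back toward a smaller chain is therefore expected to lower the number somewhat. Compound 3 is expected to show a 2.2-fold lower number from compound 2 to compound 3 (0.34 log units; beyond the scatter). The estimate for compound 3 is 350 nM, within a range of 120 nM to 1000 nM.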

Compound 3, half-maximal inhibitory concentration: 60 nM
Compound 3: middle estimate off by 5.8-fold (0.77 log units), on the high side; the whole stated range lies above it.
By their numbers in this assay, from the lowest: compound 3; then compound 1; then compound 2.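

The larger group does not always go with the higher number at this position. Replacing phenyl with methoxymethyl gives a 13-fold lower number from compound 2 to compound 3 (1.11 log units; beyond the scatter), but compound 3 also beats compound 1, which has the shorter chain: methoxy in place of methyl gives a 4.2-fold lower number from compound 1 to compound 3 (0.62 log units; beyond the scatter). The oxygen in the chain therefore goes with a lower number than size alone would suggest, at least across these three compounds. No evidence here explains this result. Going by these compounds, it remains open whether a longer chain with another ether oxygen, or an amine at the chain end, would lower the number further.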